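Butyl in place of methoxy on the shared core

A few compounds are considered here, and "the series" means these few. Any claim that something is new, unique, unknown or untested is made for them only; others in the source may bear on it.

Measured in a functional assay on the whole organism for inhibition, with Rattus norvegicus as the target, at a dose of 10 mg/kg by the oral route; a lower number here means a weaker effect, a higher number a stronger effect of the compound at the dose given:
compound 1 `O=C(Nc1nn[nH]n1)c1cccc(CCc2ccccc2)n1`: 45%
compound 2 `O=C(Nc1nn[nH]n1)c1cccc(Br)n1`: 48%
compound 3 `COc1cccc(C(=O)Nc2nn[nH]n2)n1`: 58%

Compound 3 holds the highest of the three numbers, but compound 2 comes within the scatter of it, and only compound 1 lies beyond the scatter below it. Compound 4 `CCCCc1cccc(C(=O)Nc2nn[nH]n2)n1` is compound 3 with one change: butyl in place of methoxy on an aromatic carbon.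

Among the measured compounds shown here, only one measured step touches the same aromatic carbon: a number 10 percentage points higher from compound 2 to compound 3 (within the scatter), a change that stayed within the scatter, so swapping a halogen for methoxy moved nothing that can be trusted. For the measured compounds named here, compound 1, the one compound carrying a carbon chain at that aromatic carbon, gives 45%, which sits beyond the scatter below compound 3, though no single-point step connects those two structures and only the two values themselves can be compared.

Going by the values given here, no measured step matches a methoxy to butyl exchange. The expectation in this assay is therefore a step of no trustworthy size, with a slight lean downward suggested by the number of compound 1. Compound 4 is estimated at 48%, with a range from 35% to 62%. That estimate amounts to an expected a number 10 percentage points lower from compound 3 to compound 4 (within the scatter).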

Compound 4, a percentage reported as inhibition, in the whole organism at one dose (the size of the read-out at that dose, not a potency): 18%
Beside the measured number, compound 4's estimate is 30 percentage points above it; the measured number lies below the stated range.
By their numbers in this assay, from the lowest: compound 4; then compounds 1, 2 and 3 (each within the scatter of the next, the first and the last beyond it).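

At this aromatic carbon next to the ring nitrogen, the one earlier step stayed within the scatter, so the position had not yet shown that the choice of group could matter in this assay. Butyl changes that, with a number 40 percentage points lower from compound 3 to compound 4 (beyond the scatter) and a number 30 percentage points lower from compound 2 to compound 4 (beyond the scatter), so this place does respond to the group it carries, and methoxy and bromo both give way to butyl by more than the scatter. A carbon chain here does not by itself set the read-out either: ethyl in place of phenyl on a saturated chain carbon gives a number 27 percentage points lower from compound 1 to compound 4 (beyond the scatter), and nothing available explains any of these losses.

On these data alone, whether a methyl group, a longer chain such as hexyl, an amine or a carboxylic acid at this aromatic carbon would stay near compound 3 or fall towards compound 4 remains open. As far as these compounds go, each number also belongs to a single oral dose, and whether other doses would keep the same order remains open too.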